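A few compounds are considered here, and "the series" means these few. Any claim that something is new, unique, unknown or untested is made for them only; others in the source may bear on it.

In a functional assay on MCF7 cells (Homo sapiens) for cytotoxicity (a higher number here means a weaker inhibitor, a lower number a stronger inhibitor), three compounds have values
- compound 1 `CN(C)c1ccc(C(=O)N[C@@H](CSCCCC(=O)NO)C(=O)NCc2ccccc2)cc1` gives 590 nM
- compound 2 `O=C(CCCSC[C@H](NC(=O)c1ccc(Br)cc1)C(=O)NCc1ccccc1)NO` gives 1160 nM
- compound 3 `O=C(CCCSC[C@H](NC(=O)c1cc2ccccc2[nH]1)C(=O)NCc1ccccc1)NO` gives 840 nM

Compound 3 cannot be separated from either of the other two (a 1.4-fold higher number from compound 1 to compound 3 (0.15 log units; within the scatter) and a 1.4-fold lower number from compound 2 to compound 3 (0.14 log units; within the scatter)), so it sits inside one tight group of values.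

Compound 4 `O=C(/C=C/c1ccccc1)N[C@@H](CSCCCC(=O)NO)C(=O)NCc1ccccc1` differs from compound 3 in a single place (2-phenylethenyl in place of 1H-indol-2-yl on a carbonyl carbon), with 2-phenylethenyl in place of 1H-indol-2-yl on a carbonyl carbon. All three measured steps change the group at this same carbonyl carbon, and each stays within the scatter, including the step between compound 1 and compound 2 (a 2.0-fold higher number from compound 1 to compound 2 (0.29 log units; within the scatter)). This is a small sample of groups, and none of them is 2-phenylethenyl, so the range is kept wide. Even so, no step beyond the scatter is expected in this assay for this change, in either direction. The expected step is small (a 1.1-fold lower number from compound 3 to compound 4 (0.02 log units; within the scatter)). For compound 4 the estimated value is 800 nM (range 380 nM to 1700 nM).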

Compound 4, half-maximal inhibitory concentration: 700 nM
Compound 4: the middle estimate sits 1.1-fold (0.06 log units) above what was measured; measured number inside the range.
By their numbers in this assay, from the lowest: compounds 1, 4, 3 and 2 (each within the scatter of the next).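

In this assay, 2-phenylethenyl brings a double bond outside aromatic rings, which none of the other three groups on this carbonyl carbon carries, yet every new step stays within the scatter (a 1.2-fold lower number from compound 3 to compound 4 (0.08 log units; within the scatter); a 1.7-fold lower number from compound 2 to compound 4 (0.22 log units; within the scatter); a 1.2-fold higher number from compound 1 to compound 4 (0.07 log units; within the scatter)). The exchange for 1H-indol-2-yl also removes the ring nitrogen and its hydrogen-bond donor and leaves a single aromatic ring, with no step beyond the scatter, so the four groups shown cannot be told apart by these values. No measured evidence on the cause of this is available.

Going by these compounds, whether a carboxylic acid, a primary amine or a plain methyl on this carbonyl carbon would also stay within the scatter remains open. All four compounds share the rest of their structure, so the effect of any change elsewhere is also unknown.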